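Replacing the ester of compound 1 with an oxadiazole

The source may report more compounds than this note shows. Statements on the series, on what has been measured and on what is new or still open speak of the compounds shown alone.

Compound 1 `CCOC(=O)c1cnc2ccc(-c3cccc(N)c3)cc2c1` gives > 7400 nM in a functional assay on RD cells (Homo sapiens) for inhibition, read by luminescence and ATP content, with a stated time of 72 h (on this read-out higher numbers stand for lower toxicity in this test and lower numbers for higher toxicity in this test), which is a limit of the assay, not a number. Compound 2 `CCOC(=O)c1cnc2ccc(-c3ccccc3)cc2c1` gives > 7400 nM, also a limit. Compound 3 `CCOC(=O)c1cnc2ccc(-c3ccc(N)cc3)cc2c1` gives > 7400 nM, again a limit.

All three values sit at the same limit (the limit of > 7400 nM in this assay, at which 3 of the 3 values shown sit), so the steps are unreadable: a step that the two limits leave unreadable from compound 1 to compound 2 and a step that the two limits leave unreadable from compound 1 to compound 3. Compound 4 `CCc1nc(-c2cnc3ccc(-c4cccc(N)c4)cc3c2)no1` differs from compound 1 by 5-ethyl-1,2,4-oxadiazol-3-yl in place of ethoxycarbonyl on an aromatic carbon. For the measured compounds named here, no measured step concerns this replacement, and the steps that start from compound 1 show no readable size. Compound 4 is therefore expected to give 10000 nM (range 4000 nM to 30000 nM), most likely again as a limit, meaning an expected step that the limit leaves unreadable from compound 1 to compound 4.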

Compound 4, half-maximal cytotoxic concentration: > 7400 nM
Compound 4 gave a limit, no number; the forecaster's own chance of this, stated with the estimate: 80%; the middle value lies beyond the limit too.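

Compound 1 and compound 4 both sit at a limit of this assay, not at a number, so no step between them can be read: the limit of > 7400 nM in this assay, at which 4 of the 4 values shown sit.

Going by these compounds, how toxic these four compounds actually are, and whether 5-ethyl-1,2,4-oxadiazol-3-yl in place of ethoxycarbonyl changes that toxicity, stays open.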